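Indole Methyl Position Shift on a Melanocortin-4 Ligand

The source may hold more compounds than are shown below. What is called first, only, known or untested is meant among the compounds shown, and "the series" means these compounds.

Three amides built on a shared core have been measured in an assay on HEK293 cells for displacement of a labelled ligand from Melanocortin receptor 4 (Homo sapiens); on this read-out higher numbers stand for weaker inhibition and lower numbers for stronger inhibition. Compound 1 `CC(C)C[C@H](N)c1cc(C(F)(F)F)ccc1N1CCN(C(=O)CCc2ccccc2Cl)CC1` gives 1700 nM, compound 2 `COc1cccc(CCC(=O)N2CCN(c3ccc(C(F)(F)F)cc3[C@@H](N)CC(C)C)CC2)c1` gives 4000 nM, and compound 3 `CC(C)C[C@H](N)c1cc(C(F)(F)F)ccc1N1CCN(C(=O)CCc2cn(C)c3ccccc23)CC1` gives 3000 nM, the second highest of the three values. Compound 4 `Cc1[nH]c2ccccc2c1CCC(=O)N1CCN(c2ccc(C(F)(F)F)cc2[C@@H](N)CC(C)C)CC1` differs from compound 3 in that (2-methyl-1H-indol-3-yl in place of 1-methyl-1H-indol-3-yl on a saturated chain carbon, two bonds along the chain from a carbonyl carbon). Two earlier exchanges at this chain position, a 1.8-fold higher number from compound 1 to compound 3 (0.25 log units; within the scatter) and a 1.3-fold lower number from compound 2 to compound 3 (0.12 log units; within the scatter), stayed within the scatter, and only a 2.4-fold higher number from compound 1 to compound 2 (0.37 log units; beyond the scatter) went beyond it. A comparably small move is expected here, with no clear direction, as an estimated step of no change at the digits printed from compound 3 to compound 4 (within the scatter). Compound 4 is therefore expected to give about 3000 nM in this assay, within a range from 1400 nM to 6500 nM.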

Compound 4, inhibition constant: 1600 nM
Compound 4: middle estimate off by 1.9-fold (0.27 log units), on the high side; low and high end bracket the measured number.
By their numbers in this assay, from the lowest: compounds 4, 1, 3 and 2 (each within the scatter of the next, the first and the last beyond it).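

Exchanging 1-methyl-1H-indol-3-yl for 2-methyl-1H-indol-3-yl, with the same atoms joined differently, gives a 1.9-fold lower number from compound 3 to compound 4 (0.27 log units; within the scatter) in this assay, so this exchange stays within the scatter. Yet 2-methyl-1H-indol-3-yl separates from 3-methoxyphenyl, with a 2.5-fold lower number from compound 2 to compound 4 (0.40 log units; beyond the scatter), which 1-methyl-1H-indol-3-yl did not do, while it cannot be told from 2-chlorophenyl, with a 1.1-fold lower number from compound 1 to compound 4 (0.03 log units; within the scatter). Nothing available explains these numbers.

Open, from the compounds shown here alone, is how an unsubstituted 1H-indol-3-yl group would read at this position. Also open, going by these compounds, is whether a longer chain carrying 2-methyl-1H-indol-3-yl would hold the value.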